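Aryl-triazole substituent scan, cytotoxicity read-out

This account rests on a few compounds, and the source may have more. Where it says the series, first, only, none or still open, it means among the compounds named here.

Compound 2 `COc1ccc(/C=C\C(=O)O)c(OCc2cn(-c3ccccc3)nn2)c1CC=C(C)C` carries a plain phenyl on the triazole. In a functional assay on A-431 cells (Homo sapiens) for cytotoxicity, read by MTT assay, with a stated time of 24 h (on this read-out higher numbers stand for weaker inhibition and lower numbers for stronger inhibition), compound 2 gives 21200 nM, the second highest of the three numbers in hand. Its nearest neighbour is compound 3 `COc1ccc(/C=C\C(=O)O)c(OCc2cn(-c3ccccc3C(=O)N3CCC(O)C3)nn2)c1CC=C(C)C`, which in this assay gives 31500 nM; the step of a 1.5-fold higher number from compound 2 to compound 3 (0.17 log units; within the scatter) stays within the scatter. Furthest is compound 1 `COc1ccc(/C=C\C(=O)O)c(OCc2cn(-c3ccccc3F)nn2)c1CC=C(C)C`, which in this assay gives 12400 nM; the step of a 1.7-fold higher number from compound 1 to compound 2 (0.23 log units; within the scatter) also stays within the scatter, and only a 2.5-fold higher number from compound 1 to compound 3 (0.40 log units; beyond the scatter) reaches modest size.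

Compound 4 `COc1ccc(/C=C\C(=O)O)c(OCc2cn(-c3cccc([N+](=O)[O-])c3)nn2)c1CC=C(C)C` is not yet measured. Relative to compound 2 the change is nitro in place of hydrogen on an aromatic carbon, phenyl to 3-nitrophenyl, meta to a large group. The measured steps that bear on it are the two exchanges at the same ring, a 1.7-fold higher number from compound 1 to compound 2 (0.23 log units; within the scatter) and a 1.5-fold higher number from compound 2 to compound 3 (0.17 log units; within the scatter), neither beyond the scatter. On that basis, for compound 4 the expected step is a 1.0-fold lower number from compound 2 to compound 4 (0.00 log units; within the scatter), nothing beyond the scatter. Compound 4 is accordingly estimated at 21000 nM, with a range from 8000 nM to 55000 nM.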

Compound 4, half-maximal inhibitory concentration: 18400 nM
Beside the measured number, compound 4's estimate is 1.1-fold (0.06 log units) above it; measured number inside the range.
By their numbers in this assay, from the lowest: compounds 1, 4, 2 and 3 (each within the scatter of the next, the first and the last beyond it).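

Nitro on an aromatic carbon, meta to a large group, is accommodated in this assay without a readable shift: the step is a 1.2-fold lower number from compound 2 to compound 4 (0.06 log units; within the scatter), so phenyl to 3-nitrophenyl leaves this position's number no different from that of the unsubstituted ring. The exchange of 3-nitrophenyl for 2-fluorophenyl, a 1.5-fold higher number from compound 1 to compound 4 (0.17 log units; within the scatter), is equally unresolved, so the two substituted rings cannot be ranked on this read-out. Nothing on hand explains why this position shows so little response to a nitro group.

As far as these compounds go, whether an amine or a carboxylic acid at this same ring carbon would produce a step beyond the scatter remains open. Also open, from the compounds shown here alone, is whether nitro on other carbons of the ring would behave as it does here.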